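Swapping the alkyl amine for an aryl amine

The source may report more compounds than this note shows. Statements on the series, on what has been measured and on what is new or still open speak of the compounds shown alone.

In an in vitro assay on HEK-tsA201 cells for antagonist activity at Neuronal acetylcholine receptor; alpha4/beta2 (Homo sapiens), read by fluorescence and calcium flux (on this read-out lower numbers stand for stronger inhibition and higher numbers for weaker inhibition), two compounds have been measured:
compound 1 `CCCOc1ccc(C(=O)Nc2cccc(C)n2)cc1`: 7500 nM
compound 2 `CCCCCCNc1cccc(NC(=O)c2ccc(OCCC)cc2)n1`: only a limit, > 100000 nM, that is the limit of > 100000 nM in this assay, at which 1 of the 2 values shown sits.

Compound 2 therefore stands at the limit of the measurement, the weak end of the pair. For the measured compounds named here, the single measured step is an at least 13-fold higher number from compound 1 to compound 2 (1.12 log units; beyond the scatter). Compound 3 `CCCOc1ccc(C(=O)Nc2cccc(Nc3ccc(Cl)cc3)n2)cc1` differs from compound 2 by 4-chlorophenyl in place of hexyl on a nitrogen on an aromatic ring. Going by the values given here, no measured step compares an alkyl with an aryl group on that nitrogen, so the expectation rests on compound 2 sitting at the limit. Compound 3 is expected to remain weak, with an at least 1.6-fold lower number from compound 2 to compound 3 (0.22 log units; that floor lies within the scatter) as the estimated step. Compound 3 is estimated at 60000 nM, between 8000 nM and 300000 nM.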

Compound 3, half-maximal inhibitory concentration: > 100000 nM
Compound 3: a limit, no number; the forecaster's own chance of this, stated with the estimate: 50%; middle value at least 1.6-fold (0.22 log units) from the limit.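

With an aryl group on the nitrogen, compound 3 gives > 100000 nM, a limit of the assay and not a number. Putting (4-chlorophenyl)amino in place of methyl gives an at least 13-fold higher number from compound 1 to compound 3 (1.12 log units; beyond the scatter), so at this position a ring on the nitrogen, like the hexyl chain, brings no measurable inhibition. The step between compound 2 and compound 3 cannot be read, because both stand at the same limit: the limit of > 100000 nM in this assay, at which 2 of the 3 values shown sit.

From the compounds shown here alone, whether an unsubstituted amino group or a methoxy group at this position would give a measurable value stays open. Going by these compounds, how weak compound 2 and compound 3 really are also stays open.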